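Adding an Acetyl Group to Compound 2

The source may hold more compounds than are shown below. What is called first, only, known or untested is meant among the compounds shown, and "the series" means these compounds.

Compound 1 `COC(=O)c1ccc(-c2nnc(SC3=CS(=O)(=O)c4ccccc43)o2)cc1`: 18000 nM
Compound 2 `Nc1ccc(-c2nnc(SC3=CS(=O)(=O)c4ccccc43)o2)cc1`: 24000 nM

Both compounds were tested in an ADME assay on HepG2 cells (Homo sapiens) for cytotoxicity, read by fluorescence and resazurin assay, with a stated time of 24 h; a higher number here means that more compound is tolerated, a lower number that less compound is tolerated. There, compound 2 gives 24000 nM and cannot be told apart from compound 1, with a 1.3-fold higher number from compound 1 to compound 2 (0.12 log units; within the scatter). The next compound to be measured is compound 3 `CC(=O)Nc1ccc(-c2nnc(SC3=CS(=O)(=O)c4ccccc43)o2)cc1`, which differs from compound 2 by acetyl in place of hydrogen on a nitrogen on an aromatic ring. The amino group of compound 2 thus becomes an acetamido group in compound 3.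

Within the data shown here, only one measured step bears on this change, and it bears only indirectly. It put amino in place of methoxycarbonyl on an aromatic carbon, and it did not leave the scatter: a 1.3-fold higher number from compound 1 to compound 2 (0.12 log units; within the scatter). Among the measured compounds shown here, no measured compound carries the acetamido group, so this single step is thin evidence. Still, it gives no reason to expect a large move in this assay, and no step beyond the scatter is expected in either direction. The expected step is a 1.2-fold lower number from compound 2 to compound 3 (0.08 log units; within the scatter). For compound 3 the estimate is 20000 nM, with an expected range from 9000 nM to 42000 nM.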

Compound 3, half-maximal cytotoxic concentration: 31000 nM
Compound 3: middle estimate off by 1.6-fold (0.19 log units), on the low side; measured number inside the range.
By their numbers in this assay, from the lowest: compounds 1, 2 and 3 (each within the scatter of the next).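

Putting acetyl on the nitrogen of compound 2 gives a 1.3-fold higher number from compound 2 to compound 3 (0.11 log units; within the scatter) in this assay and so leaves the amino and acetamido forms indistinguishable at this position. Replacing the methoxycarbonyl group of compound 1 with acetamido gives a 1.7-fold higher number from compound 1 to compound 3 (0.24 log units; within the scatter) and also stays within the scatter, so this read-out separates none of the three groups now seen on this aromatic carbon. The earlier compounds had shown this only for amino and methoxycarbonyl, whereas the acetamido group now gives a direct measurement, including a step on the nitrogen itself, though no supporting measurement accounts for these results. On these data alone, whether another group on this nitrogen, such as a longer acyl chain or a methanesulfonyl group, would move the number beyond the scatter remains open. As far as these compounds go, it is equally open whether a carboxylic acid or a dimethylamino group on the aromatic carbon would do so, or whether the same small steps would appear with a different core.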